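This account rests on a few compounds, and the source may have more. Where it says the series, first, only, none or still open, it means among the compounds named here.

Measured compounds:
- Compound 1 `C[C@@H]1CC(=O)N(c2cnc(NCc3c(F)ccc4c3CCO4)n3cnnc23)C1` gives 1.8 in a physicochemical assay for lipophilicity, using the shake flask method, in phosphate buffer, measured as octanol-water partition, with a stated time of 30 min, at pH 7.4; a higher number here means a more lipophilic compound, a lower number a more polar compound.
- Compound 2 `CC1(C)CC(=O)N(c2cnc(NCc3c(F)ccc4c3CCO4)n3cnnc23)C1` gives 2 in this assay.
- Compound 3 `CN(c1ccn(C)n1)c1cnc(NCc2c(F)ccc3c2CCO3)n2cnnc12` gives 1.8 in this assay.

Compound 3 sits level with compound 1, and together they are the lowest of the three numbers; the step of no change at the digits printed from compound 1 to compound 3 (within the scatter) is within the scatter, and so is a number 0.20 log units lower from compound 2 to compound 3 (within the scatter). All three compounds share the same core and differ only in one group on an aromatic carbon.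

Compound 4 `Fc1ccc2c(c1CNc1ncc(Nc3ccccc3)c3nncn13)CCO2` is not yet measured in this assay. It differs from compound 3 in one place: anilino in place of methyl(1-methyl-1H-pyrazol-3-yl)amino on an aromatic carbon. Going by the values given here, none of the measured steps covers this exchange: the two steps that touch compound 3 swap the methyl(1-methyl-1H-pyrazol-3-yl)amino for a pyrrolidinone group, not for anilino, and both stayed within the scatter. With a five-membered aromatic ring with 2 hetero atoms leaving and a six-membered aromatic ring of carbon only entering, a step upward beyond the scatter is expected for compound 4, a number 0.70 log units higher from compound 3 to compound 4 (beyond the scatter). The estimate for compound 4 is 2.5, with a range from 2 to 3.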

Compound 4, distribution coefficient: 3.3
Estimate against measurement, compound 4: 0.80 log units below; the whole stated range lies below it.
By their numbers in this assay, from the lowest: compounds 1, 3 and 2 (each within the scatter of the next); then compound 4.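

In this assay the earlier groups on this aromatic carbon stayed within the scatter of one another, so the position could have seemed to leave the number largely unmoved. Anilino changes that picture: it gives a number 1.50 log units higher from compound 3 to compound 4 (beyond the scatter) in place of methyl(1-methyl-1H-pyrazol-3-yl)amino, a number 1.30 log units higher from compound 2 to compound 4 (beyond the scatter) in place of 4,4-dimethyl-2-oxopyrrolidin-1-yl and a number 1.50 log units higher from compound 1 to compound 4 (beyond the scatter) in place of 4-methyl-2-oxopyrrolidin-1-yl. A single exchange at this position can therefore move the number well beyond the scatter, and the step is large against all three earlier groups.

Nothing available here says what lies behind this step. Going by these compounds, it also remains open whether the step goes with the hydrogen on the anilino nitrogen or with the carbon-only ring, which a methyl(phenyl)amino or a pyridin-3-ylamino group on the same carbon could help to separate.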